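A few compounds are considered here, and "the series" means these few. Any claim that something is new, unique, unknown or untested is made for them only; others in the source may bear on it.

Compound 1 `CC(C)n1cnc2c(Nc3ccccc3)nc(NCOCc3ccc(/C=C/C(=O)Nc4ccccc4N)cc3)nc21` is the higher of the two compounds measured in a functional assay on NCI-H460 cells (Homo sapiens) for antiproliferative activity, read by CCK-8 assay, with a stated time of 72 h, tested at 2 uM; a higher number here means a stronger effect of the compound at the concentration tested, a lower number a weaker effect: in this assay compound 1 gives 41%. Compound 2 `CC(C)n1cnc2c(Nc3cccc(Cl)c3)nc(NCOCc3ccc(C(=O)Nc4ccccc4N)cc3)nc21` differs from compound 1 in several places. In this assay compound 2 gives 28.9%, and the gap between the two lies beyond the usual scatter of repeated measurements. No single-change comparison between measured compounds is available.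

Compound 3 `Nc1ccccc1NC(=O)/C=C/c1ccc(COCNc2nc(Nc3ccccc3)c3ncn(C4CCCC4)c3n2)cc1` has not yet been measured. It differs from compound 1 in one place only: cyclopentyl in place of isopropyl on an aromatic nitrogen. Within the data shown here, no pair of measured compounds shows what such a swap does, and the expected step is uncertain. The change is small in size, and the step is estimated to lie within or close to the scatter, as a number 4 percentage points higher from compound 1 to compound 3 (within the scatter). Compound 3 is therefore expected to give about 45% in this assay, within a range from 30% to 60%.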

Compound 3, a percentage reported as inhibition, at one concentration (the size of the read-out at that concentration, not a potency): 52%
For compound 3 the middle estimate is 7 percentage points below the measured one; low and high end bracket the measured number.
By their numbers in this assay, from the lowest: compound 2; then compound 1; then compound 3.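

Among these compounds, the swap of isopropyl for cyclopentyl on an aromatic nitrogen gives the first single-change comparison in this assay, and the outcome is a number 11 percentage points higher from compound 1 to compound 3 (beyond the scatter). This shows that the read-out responds to the group at this position, even though the change adds only carbon atoms and a ring, with no hydrogen-bond donor or acceptor on either side. No measurement is available that explains this step.

The compounds shown cannot separate the effect of the ring from that of the added carbon atoms, a question that an open chain such as n-pentyl or a larger ring such as cyclohexyl could address. As far as these compounds go, it also remains open whether a ring carrying oxygen, such as tetrahydropyranyl, would fit this position equally well, and whether the same swap would raise the number for compound 2.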